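Working notes: from compound 3 to compound 4

The source may hold more compounds than are shown below. What is called first, only, known or untested is meant among the compounds shown, and "the series" means these compounds.

Measured compounds:
compound 1, `N/C(=N\NC(=S)N1CCN(c2ccccn2)CC1)c1ccc(F)cn1`, gives 43% in a functional assay on A-431 cells (Homo sapiens) for cytotoxicity, read by MTT assay, with a stated time of 72 h, tested at 3 uM; a lower number here means less inhibition of growth, a higher number more inhibition of growth at the concentration tested
compound 2, `Cc1ccnc(/C(N)=N/NC(=S)N2CCOCC2)c1`, gives 35.5% in this assay
compound 3, `Cc1cccc(/C(N)=N/NC(=S)N2CCSCC2)n1`, gives 51.7% in this assay

Compound 3 stands highest of the three numbers in this assay. Its nearest neighbour is compound 1, whose number lies within the scatter of compound 3, so no order between these two can be claimed. Compound 2 is the furthest away, and that gap lies beyond the scatter. The three compounds differ from one another in more than one place, so none of these gaps can be tied to a single structural change.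

Compound 4, `N/C(=N\NC(=S)N1CCSCC1)c1ccccn1`, is not yet measured. It differs from compound 3 by hydrogen in place of methyl on an aromatic carbon. Among the compounds with values here, no pair of measured compounds shows this change on its own, so there is no measured step to lean on. The expectation is that the step from compound 3 to compound 4 in this assay stays small, a number 6.7 percentage points lower from compound 3 to compound 4 (within the scatter), and most likely within the scatter, perhaps slightly downward. For compound 4 the estimated value in this assay is 45%, with a range from 30% to 60%.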

Compound 4, percent growth inhibition at one concentration: 37.2%
Compound 4: the middle estimate sits 7.8 percentage points above what was measured, within the range that was stated.
By their numbers in this assay, from the lowest: compounds 2, 4, 1 and 3 (each within the scatter of the next, the first and the last beyond it).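

In this assay, within the data shown here, hydrogen in place of methyl on an aromatic carbon, next to the ring nitrogen, gives a number 14.5 percentage points lower from compound 3 to compound 4 (beyond the scatter) and this is the first change that can be read on its own. The position is therefore not indifferent to this change: with the rest of the structure held constant, the methyl compound carries the higher number at the concentration tested. Nothing at hand says what lies behind this step.

The compounds shown leave open whether an ethyl group, a methoxy group or a chlorine atom on the same carbon would go with a higher or a lower number than methyl. Among these compounds, they also leave open whether the methyl-to-hydrogen step keeps its size when the group at the other end of the molecule is the one carried by compound 1 or compound 2.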